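This account rests on a few compounds, and the source may have more. Where it says the series, first, only, none or still open, it means among the compounds named here.

In a functional assay on MDA-MB-435 cells (Homo sapiens) for cytotoxicity, read by MTT assay, with a stated time of 72 h (on this read-out lower numbers stand for stronger inhibition and higher numbers for weaker inhibition), compound 1 (`O=C(NCc1ccc(F)cc1)c1nc(NCCO)c2cccnc2c1O`) gives > 20000 nM, which is a limit. Compound 2 (`C[C@@H](CO)Nc1nc(C(=O)NCc2ccc(F)cc2)c(O)c2ncccc12`) gives > 20000 nM, also a limit, and sits at the limit of > 20000 nM in this assay, at which 2 of the 3 values shown sit. Compound 3 (`CNCCCNc1c(C(=O)NCc2ccc(F)cc2)nc(Br)c2cccnc12`) gives 11000 nM. Compound 4 (`C[C@H](CO)Nc1nc(C(=O)NCc2ccc(F)cc2)c(O)c2ncccc12`) relates to compound 2 as follows: the two compounds have the same atoms and bonds and differ only in configuration as drawn: 1 of 1 stereo elements differ; a stereocentre at a saturated chain carbon is drawn S in compound 2 and R in compound 4. Among the measured compounds shown here, the only measured step touching this region is a step that the two limits leave unreadable from compound 1 to compound 2, and its size cannot be read. For the measured compounds named here, no measured step changes configuration alone. No shift beyond the usual scatter is therefore expected in this assay, and no direction can be assigned. The estimated step is a step that the limit leaves unreadable from compound 2 to compound 4. Compound 4 is estimated at 22000 nM, with an expected range of 12000 nM to 40000 nM, and a report as a limit is likely.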

Compound 4, half-maximal inhibitory concentration: > 20000 nM
Compound 4 was reported as a limit (the forecaster's own chance of this, stated with the estimate: 80%); the middle value does not contradict the limit.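

In this assay compound 1, compound 2 and compound 4 all stand as limits, and no new step can be read among them. The compounds shown leave open whether the configuration at the saturated chain carbon has any effect on this read-out.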